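Replacing the 4-cyanophenyl group of compound 2

The source may report more compounds than this note shows. Statements on the series, on what has been measured and on what is new or still open speak of the compounds shown alone.

Going by the values given here, in a functional assay on PC-3 cells (Homo sapiens) for cytotoxicity, read by MTT assay, with a stated time of 72 h (on this read-out higher numbers stand for weaker inhibition and lower numbers for stronger inhibition), compound 1 `CNC(=O)c1cc(Oc2ccc(C3=NNC(c4ccc(Cl)cc4Cl)C3)cc2)ccn1` gives 7300 nM and compound 2 `CNC(=O)c1cc(Oc2ccc(C3=NNC(c4ccc(C#N)cc4)C3)cc2)ccn1` gives 9910 nM so compound 2 cannot be told apart from the only other measured compound. Compound 3 `CNC(=O)c1cc(Oc2ccc(C3=NNC(c4ccc(F)cc4Cl)C3)cc2)ccn1` is still unmeasured. It carries 2-chloro-4-fluorophenyl in place of 4-cyanophenyl on a saturated ring carbon. Among the compounds with values here, one measured step bears on this change, since it concerns the same carbon: 4-cyanophenyl in place of 2,4-dichlorophenyl (a 1.4-fold higher number from compound 1 to compound 2 (0.13 log units; within the scatter)). That step stayed within the scatter, and the incoming group resembles the 2,4-dichlorophenyl of compound 1 (7300 nM). No step beyond the scatter is therefore expected in this assay, and the expected step is a 1.3-fold lower number from compound 2 to compound 3 (0.12 log units; within the scatter) in size. For compound 3 the estimated value is 7500 nM with an expected range of 3500 nM to 15000 nM (an estimate, not a measurement).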

Compound 3, half-maximal inhibitory concentration: 24300 nM
For compound 3 the middle estimate is 3.2-fold (0.51 log units) below the measured one, and the stated range ends below it.
By their numbers in this assay, from the lowest: compounds 1 and 2 (each within the scatter of the next); then compound 3.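

In this assay, the group on this saturated ring carbon can shift the number beyond the scatter: there is a 2.5-fold higher number from compound 2 to compound 3 (0.39 log units; beyond the scatter), a modest step. The sharper finding is a 3.3-fold higher number from compound 1 to compound 3 (0.52 log units; beyond the scatter), where fluoro in place of chloro on an aromatic carbon is the only difference, so a small edit to this ring matters more here than the larger exchange of 2,4-dichlorophenyl for 4-cyanophenyl, which stayed within the scatter. Nothing measured here accounts for the higher number of compound 3.

The compounds shown leave open how this carbon would respond to a phenyl ring carrying a methoxy group or an amine, or to a plain phenyl ring. As far as these compounds go, it also remains open whether a bromo group in place of the fluoro would follow compound 1 or compound 3.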